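The compounds below may be only part of what the source reports. "The series", "measured", "known", "first", "only" and "open" are said of these compounds alone.

Measured compounds and their values:
compound 2 `Cc1ccc(/C=N/NC(=O)COc2cccc3ccccc23)cc1` – 4.49
compound 1 `COc1ccc(/C=N/NC(=O)COc2cccc3ccccc23)cc1OC` – 3.51
compound 3 `COc1cc(/C=N/NC(=O)COc2cccc3ccccc23)cc(OC)c1O` – 3.23

In a physicochemical assay for lipophilicity, measured as octanol-water partition (on this read-out higher numbers stand for higher lipophilicity and lower numbers for lower lipophilicity), compound 2 gives 4.49, the highest of the three numbers. Compound 1 gives 3.51, the nearest value, and the gap to compound 2 lies beyond the scatter. Compound 3 gives 3.23, the furthest value, again beyond the scatter from compound 2.

Compound 4 `O=C(COc1cccc2ccccc12)N/N=C/c1cccc(Br)c1` has not yet been measured in this assay. It differs from compound 2 in one place: 3-bromophenyl in place of 4-methylphenyl on a carbon with a double bond to nitrogen. Going by the values given here, no measured pair shows a change of this kind, so the step is expected to be small and upward, close to the edge of the scatter. The step from compound 2 to compound 4 is expected to be a number 0.26 log units higher from compound 2 to compound 4 (within the scatter). Compound 4 is therefore estimated at 4.75, between 4.45 and 5.05.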

Compound 4, partition coefficient: 4.81
Beside the measured number, compound 4's estimate is 0.06 log units below it; measured number inside the range.
By their numbers in this assay, from the lowest: compounds 3 and 1 (each within the scatter of the next); then compound 2; then compound 4.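

In this assay, going by these compounds alone, this is the first comparison that changes a single place, the group on a carbon with a double bond to nitrogen: 3-bromophenyl in place of 4-methylphenyl gives a number 0.32 log units higher from compound 2 to compound 4 (beyond the scatter) on the shared core. The two groups match in heavy atoms and hydrogen-bond counts, yet the read-out still moves modestly. Nothing available explains this shift.

From the compounds shown here alone, whether the step follows the bromine itself or the changed substituent location remains open. So does the value that a phenyl carrying an amine or a carboxylic acid would give here.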